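Swapping 3-fluorophenyl for 2-chlorophenyl: a cytotoxicity estimate

A few compounds are considered here, and "the series" means these few. Any claim that something is new, unique, unknown or untested is made for them only; others in the source may bear on it.

Three related compounds have been measured in an ADME assay on MT4 cells (Homo sapiens) for cytotoxicity, read by MTT assay, with a stated time of 96 h; a lower number here means that less compound is tolerated, a higher number that more compound is tolerated. Compound 1 `NS(=O)(=O)c1ccc(N2N=C(c3ccc(Oc4ccccc4)cc3)CC2c2ccccc2)cc1` gives 42000 nM, compound 2 `NS(=O)(=O)c1ccc(N2N=C(c3ccc(OCc4ccccc4)cc3)CC2c2ccccc2Cl)cc1` gives 26000 nM, and compound 3 `NS(=O)(=O)c1ccc(N2N=C(c3ccc(Oc4ccccc4)cc3)CC2c2cccc(F)c2)cc1` gives 25000 nM. Compound 3 therefore stands within the usual scatter of both other compounds, so these numbers cannot separate the three.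

Compound 4 `NS(=O)(=O)c1ccc(N2N=C(c3ccc(Oc4ccccc4)cc3)CC2c2ccccc2Cl)cc1` has 2-chlorophenyl in place of the 3-fluorophenyl of compound 3 on a saturated ring carbon: 2-chlorophenyl in place of 3-fluorophenyl on a saturated ring carbon.

Among the compounds with values here, one measured step bears on this change: a 1.7-fold lower number from compound 1 to compound 3 (0.23 log units; within the scatter). It is fluoro in place of hydrogen on an aromatic carbon, and it lies within the scatter. Although it differs from compound 4 elsewhere, compound 2 also carries 2-chlorophenyl, and compound 2 gives 26000 nM. Within the data shown here, no measured step isolates the new group, so a step beyond the scatter is not expected in this assay.

The estimated change is a 1.1-fold higher number from compound 3 to compound 4 (0.05 log units; within the scatter), with no clear direction expected. For compound 4, the expected value is 28000 nM, within an estimated range of 14000 nM to 55000 nM.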

Compound 4, half-maximal cytotoxic concentration: 40000 nM
Estimate against measurement, compound 4: 1.4-fold (0.15 log units) below; measured number inside the range.
By their numbers in this assay, from the lowest: compounds 3, 2, 4 and 1 (each within the scatter of the next).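

In this assay, 2-chlorophenyl on the saturated ring carbon can now be compared directly with two other groups at this position: replacing 3-fluorophenyl gives a small step (a 1.6-fold higher number from compound 3 to compound 4 (0.20 log units; within the scatter)), and chloro in place of hydrogen on the aromatic carbon gives another (a 1.1-fold lower number from compound 1 to compound 4 (0.02 log units; within the scatter)). With 2-chlorophenyl held fixed, phenyl in place of benzyl on the oxygen elsewhere in the molecule (a 1.5-fold higher number from compound 2 to compound 4 (0.19 log units; within the scatter)) also stays within the scatter, so none of these changes can be told apart from repeat-measurement noise. No measurement at hand offers a reason for any of these numbers.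

The groups at this position are phenyl, 3-fluorophenyl and 2-chlorophenyl only. As far as these compounds go, whether an amine or a carboxylic acid on that phenyl ring, or a longer chain in its place, would give a step beyond the scatter remains open.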